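Piperazine substituents and a flat read-out

The source may hold more compounds than are shown below. What is called first, only, known or untested is meant among the compounds shown, and "the series" means these compounds.

Measured in a functional assay on ECa-109 cells for inhibition, with ECa-109 cell line (Homo sapiens) as the target, read by MTT assay, with a stated time of 48 h; on this read-out higher numbers stand for weaker inhibition and lower numbers for stronger inhibition:
- compound 1 `CCN1CCN(C(=S)SCCCOc2ccc3c(=O)c(-c4ccc(OC)cc4)coc3c2)CC1`: 36900 nM
- compound 2 `COc1ccc(-c2coc3cc(OCCCSC(=S)N4CCN(Cc5ccccc5)CC4)ccc3c2=O)cc1`: 25300 nM
- compound 3 `COc1ccc(-c2coc3cc(OCCCSC(=S)N4CCN(C(C)=O)CC4)ccc3c2=O)cc1`: 24700 nM

These three compounds share a core and differ only in the group on one ring nitrogen. Compound 3, which carries acetyl there, gives 24700 nM. Its steps to the other two lie within the scatter, and no ranking can be drawn.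

The next compound is compound 4 `COc1ccc(-c2coc3cc(OCCCSC(=S)N4CCN(c5ccccn5)CC4)ccc3c2=O)cc1`, with pyridin-2-yl in place of acetyl on an amine nitrogen in a ring. Three measured steps change this same group: a 1.5-fold lower number from compound 1 to compound 3 (0.17 log units; within the scatter), a 1.0-fold lower number from compound 2 to compound 3 (0.01 log units; within the scatter) and a 1.5-fold lower number from compound 1 to compound 2 (0.16 log units; within the scatter). All three are within the scatter, even though ethyl, benzyl and acetyl are quite different groups. No step beyond the scatter is therefore expected in this assay. Among the measured compounds shown here, no measured compound carries pyridin-2-yl, however, so the range is kept wide.

The estimated step is a 1.2-fold lower number from compound 3 to compound 4 (0.07 log units; within the scatter).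

For compound 4 the expected value is 21000 nM, with an estimated range of 8000 nM to 45000 nM.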

Compound 4, half-maximal inhibitory concentration: 38300 nM
For compound 4 the middle estimate is 1.8-fold (0.26 log units) below the measured one; low and high end bracket the measured number.
By their numbers in this assay, from the lowest: compounds 3, 2, 1 and 4 (each within the scatter of the next).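

Among the compounds shown here, compound 4 is the first compound here with an aromatic ring bonded straight to the amine nitrogen in the ring, and in this assay this change stays within the scatter against all three earlier groups (a 1.6-fold higher number from compound 3 to compound 4 (0.19 log units; within the scatter)), (a 1.5-fold higher number from compound 2 to compound 4 (0.18 log units; within the scatter)) and (a 1.0-fold higher number from compound 1 to compound 4 (0.02 log units; within the scatter)). The flat read-out at this position therefore extends to pyridin-2-yl, so acetyl, ethyl, benzyl and pyridin-2-yl cannot be ranked on these four compounds. No supporting measurement bears on why the four values stay so close.

Still open, on these data alone, is whether any group on this nitrogen can move the number beyond the scatter. A carboxylic acid or a longer chain ending in an amine on this nitrogen would test that, and changes elsewhere on the shared core remain a separate question.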